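Chloro Analogue of a Pyrazoline Pair Expected Near Parent

This account rests on a few compounds, and the source may have more. Where it says the series, first, only, none or still open, it means among the compounds named here.

Measured in a functional assay on A549 cells (Homo sapiens) for antiproliferative activity, read by MTT assay, with a stated time of 24 h; a lower number here means a stronger inhibitor of growth, a higher number a weaker inhibitor of growth:
- compound 1 `NC(=S)N1N=C(c2ccc(Cl)c(Cl)c2)CC1c1ccc(O)cc1`: 33500 nM
- compound 2 `Fc1ccc(C2=NN(c3ccccc3)C(c3ccc4ccccc4c3)C2)cc1`: 230 nM
- compound 3 `c1ccc(C2=NN(c3ccccc3)C(c3ccc4ccccc4c3)C2)cc1`: 220 nM

Compound 3 holds the lowest of the three numbers in this assay, but its gap to compound 2 is within the scatter, so the two cannot be ranked against each other; compound 1, a different core with a different set of substituents, sits far higher and offers no direct comparison at this position.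

Compound 4 `Clc1ccc(C2=NN(c3ccccc3)C(c3ccc4ccccc4c3)C2)cc1` differs from compound 3 in one place: chloro in place of hydrogen on an aromatic carbon. Going by the values given here, the only measured step that touches this position is a 1.0-fold lower number from compound 2 to compound 3 (0.02 log units; within the scatter), where swapping a halogen for hydrogen on the same aromatic carbon left the number essentially unchanged. Among the compounds with values here, no other pair in the set bears on the change.

On that basis compound 4 is expected to land close to compound 3, with the step of no change at the digits printed from compound 3 to compound 4 (within the scatter) expected to stay within the scatter. Compound 4 is therefore estimated at 220 nM, with a range from 100 nM to 480 nM.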

Compound 4, concentration for 50% growth inhibition: 160 nM
Beside the measured number, compound 4's estimate is 1.4-fold (0.14 log units) above it, within the range that was stated.
By their numbers in this assay, from the lowest: compounds 4, 3 and 2 (each within the scatter of the next); then compound 1.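

In this assay, chloro on this aromatic carbon gives a 1.4-fold lower number from compound 3 to compound 4 (0.14 log units; within the scatter), and set against fluoro at the same place it gives a 1.4-fold lower number from compound 2 to compound 4 (0.16 log units; within the scatter). The earlier compounds shown here showed only that fluoro and hydrogen could not be told apart here, whereas a second halogen now gives the same outcome, so the phenyl to 4-chlorophenyl change does not separate compound 4 from either neighbour. Hydrogen, fluoro and chloro therefore stand as one group at this position in this cell assay, with no order among them.

As far as these compounds go, whether the position stays this flat with an amine, a carboxylic acid or a longer chain remains open, as does the effect of changes elsewhere on the shared core. Nothing available explains why these three compounds cannot be separated.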